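Compound 2 to compound 4: fluoro in place of chloro

The compounds below may be only part of what the source reports. "The series", "measured", "known", "first", "only" and "open" are said of these compounds alone.

In a functional assay on A2780 cells (Homo sapiens) for antiproliferative activity, read by MTT assay, with a stated time of 72 h (a higher number here means a weaker inhibitor, a lower number a stronger inhibitor), compound 1 `O=C(c1cc2ccccc2o1)N1N=C(c2ccc(Cl)cc2)CC1c1ccccc1` gives 13.6 ug/mL, compound 2 `O=C(c1cc2ccccc2o1)N1N=C(c2ccc(Cl)cc2)CC1c1ccccc1Cl` gives 44.8 ug/mL and compound 3 `COc1ccc(C2CC(c3ccc(Cl)cc3)=NN2C(=O)c2cc3ccccc3o2)cc1OC` gives 6.29 ug/mL. Compound 2 has the highest number of the three and is the weakest inhibitor among them. Compound 4 `O=C(c1cc2ccccc2o1)N1N=C(c2ccc(F)cc2)CC1c1ccccc1Cl` departs from compound 2 at one place: fluoro in place of chloro on an aromatic carbon. This is fluoro in place of chloro on an aromatic carbon, para to a large group, or 4-chlorophenyl to 4-fluorophenyl.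

The three measured steps all lie elsewhere: a 3.3-fold higher number from compound 1 to compound 2 (0.52 log units; beyond the scatter), a 2.2-fold lower number from compound 1 to compound 3 (0.33 log units; beyond the scatter) and a 7.1-fold lower number from compound 2 to compound 3 (0.85 log units; beyond the scatter). Each is modest and beyond the scatter, but compounds 1, 2 and 3 all share the 4-chlorophenyl, so no measurement tests this change directly. With no evidence for a direction, no step beyond the scatter is expected in this assay. The estimated change is a 1.2-fold lower number from compound 2 to compound 4 (0.09 log units; within the scatter). For compound 4 the expected value is 36 ug/mL, with an estimated range of 14 ug/mL to 85 ug/mL.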

Compound 4, half-maximal inhibitory concentration: 45.2 ug/mL
Compound 4: middle estimate off by 1.3-fold (0.10 log units), on the low side, within the range that was stated.
By their numbers in this assay, from the lowest: compound 3; then compound 1; then compounds 2 and 4 (each within the scatter of the next).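

In this assay, the change from 4-chlorophenyl to 4-fluorophenyl gives a 1.0-fold higher number from compound 2 to compound 4 (0.00 log units; within the scatter), the only reading at this position among the compounds shown, as compounds 1, 2 and 3 all carry the 4-chlorophenyl. With 2-chlorophenyl on the saturated ring carbon, chloro and fluoro on this aromatic carbon cannot be told apart, whereas the listed steps at the saturated ring carbon all lie beyond the scatter. No measurement at hand explains this result.

As far as these compounds go, whether the two halogens also read alike with phenyl, as in compound 1, or with 3,4-dimethoxyphenyl, as in compound 3, remains open. Also open, from the compounds shown here alone, is how an amine, a carboxylic acid or a plain hydrogen on this aromatic carbon would read in this assay.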